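The compounds below may be only part of what the source reports. "The series", "measured", "known", "first", "only" and "open" are said of these compounds alone.

Measured in a functional assay on FM3A cells (Mus musculus) for antiproliferative activity; on this read-out higher numbers stand for weaker inhibition and lower numbers for stronger inhibition:
- compound 1 `COc1cc(C(=O)c2sc(-c3ccc([N+](=O)[O-])cc3)cc2N)cc(OC)c1OC`: 64 nM
- compound 2 `COc1cc(C(=O)c2sc(-c3ccncc3)cc2N)cc(OC)c1OC`: 150 nM

Compound 1 holds the lower of the two numbers, so it is the stronger inhibitor so far. Compound 3 (`COc1cc(C(=O)c2sc(-c3ccsc3)cc2N)cc(OC)c1OC`) is still unmeasured. Its change from compound 1 is thiophen-3-yl in place of 4-nitrophenyl on an aromatic carbon, with thiophen-3-yl in place of 4-nitrophenyl on an aromatic carbon. Among the compounds with values here, the only measured step that bears on this also removes 4-nitrophenyl: a 2.3-fold higher number from compound 1 to compound 2 (0.37 log units; beyond the scatter). A similarly modest move towards weaker inhibition is therefore expected in this assay, though it may stay within the scatter. The expected step is a 1.6-fold higher number from compound 1 to compound 3 (0.19 log units; within the scatter). Compound 3 is estimated at 100 nM, with an expected range of 35 nM to 290 nM.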

Compound 3, half-maximal inhibitory concentration: 3.7 nM
The estimate for compound 3 lay 27-fold (1.43 log units) above the measured number; the whole stated range lies above it.
By their numbers in this assay, from the lowest: compound 3; then compound 1; then compound 2.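

In this assay, the position next to the ring sulfur proves far more sensitive to its substituent than the earlier pair showed, with thiophen-3-yl giving a 17-fold lower number from compound 1 to compound 3 (1.24 log units; beyond the scatter) and a 41-fold lower number from compound 2 to compound 3 (1.61 log units; beyond the scatter). A five-membered aromatic ring with 5 heavy atoms is therefore compatible with much stronger inhibition than either six-membered group, including 4-nitrophenyl with 9 heavy atoms. Nothing available explains the gain.

Still open, as far as these compounds go, is whether ring size or the sulfur atom tracks with the gain. Unsubstituted phenyl, furan-3-yl and thiophen-2-yl at this position would separate these readings.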